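The source may report more compounds than this note shows. Statements on the series, on what has been measured and on what is new or still open speak of the compounds shown alone.

Measured so far in an ADME assay on NIH3T3 cells (Mus musculus) for cytotoxicity, read by MTT assay, with a stated time of 24 h; a higher number here means a weaker inhibitor, a lower number a stronger inhibitor:
compound 1 `O=C(CSc1nnc(-c2ccncc2)o1)N/N=C/c1ccc(F)cc1` gives 170000 nM.
compound 2 `O=C(CSc1nnc(-c2ccncc2)o1)N/N=C/c1ccc([N+](=O)[O-])cc1` gives 195000 nM.
compound 3 `O=C(CSc1nnc(-c2ccncc2)o1)N/N=C/c1ccccc1F` gives 142000 nM.

Compound 1 holds the second highest of the three numbers. Its nearest neighbour is compound 2, a 1.1-fold higher number from compound 1 to compound 2 (0.06 log units; within the scatter), and its furthest is compound 3, a 1.2-fold lower number from compound 1 to compound 3 (0.08 log units; within the scatter). The remaining pair is no wider: a 1.4-fold lower number from compound 2 to compound 3 (0.14 log units; within the scatter). All three steps sit within the scatter, so among these compounds the group on the carbon with a double bond to nitrogen has not been seen to shift the read-out in this assay.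

Compound 4 `O=C(CSc1nnc(-c2ccncc2)o1)N/N=C/c1ccc(O)c(O)c1` differs from compound 1 in a single place: 3,4-dihydroxyphenyl in place of 4-fluorophenyl on a carbon with a double bond to nitrogen. For the measured compounds named here, no measured step brings in a 3,4-dihydroxyphenyl group, so the only guidance comes from the three steps above, each of which exchanged this same group without moving the number beyond the scatter. On that basis no step beyond the scatter is expected here either, with the direction left open; compound 4 is estimated to show a 1.1-fold lower number from compound 1 to compound 4 (0.03 log units; within the scatter) in this assay. The estimate for compound 4 is 160000 nM, with a range from 80000 nM to 320000 nM.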

Compound 4, half-maximal inhibitory concentration: 154000 nM
Estimate against measurement, compound 4: 1.0-fold (0.02 log units) above; the measured number falls inside the stated range.
By their numbers in this assay, from the lowest: compounds 3, 4, 1 and 2 (each within the scatter of the next).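

In this assay, the 3,4-dihydroxyphenyl group carries 2 hydrogen-bond donors and 2 hydrogen-bond acceptors where 4-fluorophenyl carries 0 of each, yet this exchange gives a 1.1-fold lower number from compound 1 to compound 4 (0.04 log units; within the scatter). The comparisons with the other two compounds read the same way, with a 1.1-fold higher number from compound 3 to compound 4 (0.04 log units; within the scatter) and a 1.3-fold lower number from compound 2 to compound 4 (0.10 log units; within the scatter), so the flat picture on the carbon with a double bond to nitrogen now covers a 3,4-dihydroxyphenyl group as well as the fluorophenyl and 4-nitrophenyl groups, and none of the four compounds goes against it. No supporting data are available to explain this flat read-out.

On these data alone, all four compounds keep a substituted phenyl group at this position, so it remains open whether an amine, a carboxylic acid or a longer alkyl chain in its place would give a step beyond the scatter in this assay. As far as these compounds go, what a change to the shared core would do to the read-out also remains open, as every comparison here holds that core fixed.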